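Adding One Fluorine to the Phenyl Ring of Compound 3

This account rests on a few compounds, and the source may have more. Where it says the series, first, only, none or still open, it means among the compounds named here.

Compound 1 `Cc1c(C(=O)Nc2ccc(Oc3ccnc4[nH]ccc34)c(F)c2)nnn1-c1ccc(F)cc1` is the starting point of this small set. In a functional assay on A549 cells (Homo sapiens) for cytotoxicity, read by MTT assay, with a stated time of 72 h (on this read-out lower numbers stand for stronger inhibition and higher numbers for weaker inhibition), compound 1 gives 150 nM. Compound 2 `Cc1c(C(=O)Nc2ccc(Oc3ccnc4[nH]ccc34)c(F)c2)nnn1-c1ccc(F)c(F)c1` differs from compound 1 in a single place: fluoro in place of hydrogen on an aromatic carbon. In this assay compound 2 gives 570 nM, and that single change brought a 3.8-fold higher number from compound 1 to compound 2 (0.58 log units; beyond the scatter).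

Compound 3 `Cc1c(C(=O)Nc2ccc(Oc3ccnc4[nH]ccc34)cc2)nnn1-c1ccccc1` carries a different core; the difference between the cores of compound 3 and compound 1 is not broken down here. In this assay compound 3 gives 420 nM. Compound 4 `Cc1c(C(=O)Nc2ccc(Oc3ccnc4[nH]ccc34)cc2)nnn1-c1ccccc1F` has not yet been measured. It differs from compound 3 in one place: fluoro in place of hydrogen on an aromatic carbon. Among the measured compounds shown here, this is the same kind of change as the one from compound 1 to compound 2, though not the same: in compound 2 the fluorine enters ortho to a fluoro group and meta to a large group, whereas in compound 4 it enters ortho to a large group, on a ring that carries no other fluoro.

For the measured compounds named here, the only measured example of adding a fluorine to this ring made the number higher. On that basis the step from compound 3 to compound 4 is expected to be a 2.0-fold higher number from compound 3 to compound 4 (0.31 log units; beyond the scatter), a somewhat smaller shift than the one seen in a 3.8-fold higher number from compound 1 to compound 2 (0.58 log units; beyond the scatter), since the surroundings of the new fluorine are not the same. Compound 4 is therefore estimated at 850 nM, with a likely range from 300 nM to 2500 nM.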

Compound 4, half-maximal inhibitory concentration: 320 nM
Beside the measured number, compound 4's estimate is 2.7-fold (0.42 log units) above it, within the range that was stated.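

In this assay, placing a fluoro group on the phenyl ring of compound 3, ortho to a large group, gave a 1.3-fold lower number from compound 3 to compound 4 (0.12 log units; within the scatter), so this pair cannot be told apart on this read-out. The same kind of change therefore did not behave alike in the two settings, and a result seen on one core could not simply be carried over to the other: the same change on two cores in this assay, a 3.8-fold higher number (0.58 log units; beyond the scatter) from compound 1 to compound 2 and a 1.3-fold lower number (0.12 log units; within the scatter) from compound 3 to compound 4, 5.0-fold (0.70 log units) apart, beyond the scatter of two such steps

Among the compounds shown here, this does not show why the two steps differ, nor that the core alone decides the outcome, since the two pairs differ in their cores, in where the fluorine enters and in whether the ring already carries a fluoro group, and with only two examples these influences cannot be separated.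

The compounds shown leave open whether phenyl to 2-fluorophenyl would give a similar result on the core of compound 1, which would help to separate the core from the position on the ring. They also leave open how a chloro group, a methoxy group or an amine at the same place on the ring of compound 3 would read in this assay.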